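This account rests on a few compounds, and the source may have more. Where it says the series, first, only, none or still open, it means among the compounds named here.

Compound 1 `COc1ccc(-c2nnc(SCC(=O)c3ccccc3)n2-c2ccccc2)cc1OC` gives 59% in a functional assay on the whole organism (strain albino) for inhibition, with Rattus norvegicus as the target, read by paw edema, with a stated time of 5 h, at a dose of 0.28 mmol/kg by the oral route; on this read-out lower numbers stand for less inhibition and higher numbers for more inhibition at the one dose given (going by the name of the read-out). Compound 2 `COc1ccc(-c2nnc(SC/C(=N/O)c3ccccc3)n2-c2ccccc2)cc1OC` gives 78% in this assay. Compound 3 `C=CCn1c(SC/C(=N/O)c2ccccc2)nnc1-c1cc(OC)c(OC)c(OC)c1` gives 77% in this assay.

Compound 2 and compound 1 share a core and differ in one place: a group of 8 heavy atoms (7 carbon, 1 oxygen; one six-membered aromatic ring of carbon only) in place of a group of 9 heavy atoms (7 carbon, 1 nitrogen, 1 oxygen; one six-membered aromatic ring of carbon only), on a saturated chain carbon bound to a sulfur. On this change the read-out moves by a number 19 percentage points lower from compound 2 to compound 1 (beyond the scatter). Compound 3 carries the same side chain as compound 2 on a different core; how the two cores differ is not broken down here. Its value and that of compound 2 lie within the usual scatter of each other, so the two cores behave alike on this read-out as far as these two numbers show.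

Compound 4 `C=CCn1c(SCC(=O)c2ccccc2)nnc1-c1cc(OC)c(OC)c(OC)c1` has not yet been measured in this assay. It differs from compound 3 by a group of 8 heavy atoms (7 carbon, 1 oxygen; one six-membered aromatic ring of carbon only) in place of a group of 9 heavy atoms (7 carbon, 1 nitrogen, 1 oxygen; one six-membered aromatic ring of carbon only), on a saturated chain carbon bound to a sulfur, which is the same change that turns compound 2 into compound 1. Because that earlier change gave a number 19 percentage points lower from compound 2 to compound 1 (beyond the scatter), a step of similar size is expected here, estimated as a number 19 percentage points lower from compound 3 to compound 4 (beyond the scatter). Compound 4 is therefore expected to give about 58% in this assay, with the estimate spanning from 46% to 70%.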

Compound 4, a percentage reported as inhibition, in the whole organism at one dose (the size of the read-out at that dose, not a potency): 60%
Estimate against measurement, compound 4: 2 percentage points below; low and high end bracket the measured number.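

In this assay, putting benzoyl in place of the group it replaces, on a saturated chain carbon bound to a sulfur, moves the read-out by a number 17 percentage points lower from compound 3 to compound 4 (beyond the scatter). The change therefore carries over from one core to the other with much the same size, and the two steps cannot be told apart: the same change on two cores in this assay, a number 19 percentage points lower (beyond the scatter) from compound 2 to compound 1 and a number 17 percentage points lower (beyond the scatter) from compound 3 to compound 4, 2 percentage points apart, within the scatter of two such steps This shows that the change behaved alike on these two cores, at the one dose and the one time given, but it does not show that the same step would appear on any other core, and it gives no reason for the step.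

The compounds shown leave open how the read-out would respond to other groups on that saturated chain carbon, such as an amine, a carboxylic acid or a longer chain. They also leave open whether the step keeps its size at other doses or at other times.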